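The source may report more compounds than this note shows. Statements on the series, on what has been measured and on what is new or still open speak of the compounds shown alone.

Series notes. Compound 1, `FC(F)(F)c1ccc(COc2nc3ccccc3s2)cc1`, was run in a functional assay on the whole organism with Mus musculus as the target, with a stated time of 1 h, at a dose of 100 mg/kg by the intraperitoneal route (on this read-out lower numbers stand for less inhibition and higher numbers for more inhibition at the one dose given (going by the name of the read-out)), where compound 1 gives 12.2%, the lowest of the two numbers in hand. Compound 2, `Clc1ccc(OCCOc2nc3ccccc3s2)c(Cl)c1`, gives 85.4% in this assay, a gap from compound 1 that lies beyond the scatter. Compound 3, `N#Cc1ccc(COc2nc3ccccc3s2)cc1`, is not yet measured; relative to compound 1 the change is cyano in place of trifluoromethyl on an aromatic carbon. Within the data shown here, no measured pair carries this change, so the size of the step is not anchored by the present numbers. The expected step is a number 9.8 percentage points higher from compound 1 to compound 3 (within the scatter), taken as small and possibly within the scatter. Compound 3 is estimated at 22% in this assay, with a range from 3% to 50%.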

Compound 3, a percentage reported as inhibition, in the whole organism at one dose (the size of the read-out at that dose, not a potency): 12.7%
The estimate for compound 3 lay 9.3 percentage points above the measured number, and the stated range covers the measured number.
By their numbers in this assay, from the lowest: compounds 1 and 3 (each within the scatter of the next); then compound 2.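

Working notes: in this assay, cyano in place of trifluoromethyl on an aromatic carbon, para to a large group, gives a number 0.5 percentage points higher from compound 1 to compound 3 (within the scatter), the first measured step for this change. At this position, the two groups therefore cannot be told apart on this read-out. Nothing at hand bears on why they read alike.

The compounds shown leave open whether an amine or a carboxylic acid on this aromatic carbon would give a step beyond the scatter. They also leave open what a longer chain in the linker would do with the ring substituent held fixed.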